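The source may hold more compounds than are shown below. What is called first, only, known or untested is meant among the compounds shown, and "the series" means these compounds.

Among the compounds with values here, compound 2 `O=C(CCCCCCc1ccccc1)c1ncc(-c2ccc([N+](=O)[O-])cc2)o1` gives 50 nM in an assay (Rattus norvegicus) for inhibition of Fatty-acid amide hydrolase 1 (Homo sapiens) (a lower number here means a stronger inhibitor, a higher number a weaker inhibitor), the lowest of the two numbers known here. Within the data shown here, compound 1 `N#Cc1ccccc1-c1cnc(C(=O)CCCCCCc2ccccc2)o1` gives 130 nM in this assay, and the only measured step, a 2.6-fold lower number from compound 1 to compound 2 (0.41 log units; beyond the scatter), changes the same group on the same aromatic carbon. Compound 3 `O=C(O)c1ccc(-c2cnc(C(=O)CCCCCCc3ccccc3)o2)cc1` differs from compound 2 by carboxy in place of nitro on an aromatic carbon. Among the measured compounds shown here, no measured step tests a carboxy group, so the direction is uncertain; a modest change, within or only slightly beyond the scatter, is expected, as a 2.0-fold higher number from compound 2 to compound 3 (0.30 log units; within the scatter). Compound 3 is therefore estimated at 100 nM, likely between 25 nM and 400 nM.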

Compound 3, inhibition constant: 60 nM
Beside the measured number, compound 3's estimate is 1.7-fold (0.22 log units) above it; the measured number falls inside the stated range.
By their numbers in this assay, from the lowest: compounds 2 and 3 (each within the scatter of the next); then compound 1.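

In this assay, carboxy in place of nitro gives a 1.2-fold higher number from compound 2 to compound 3 (0.08 log units; within the scatter) and so leaves the number essentially unchanged, even though carboxy carries a hydrogen-bond donor and nitro does not. The 4-carboxyphenyl group, like 4-nitrophenyl, also compares well with 2-cyanophenyl, with a 2.2-fold lower number from compound 1 to compound 3 (0.34 log units; beyond the scatter) as the step between them. Nothing measured here explains either result. Still open, on these data alone, is whether that gain follows the group or its place on the ring, which a 4-cyanophenyl compound could separate. How an amine or a methyl ester would behave at this position is also unknown.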